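This account rests on a few compounds, and the source may have more. Where it says the series, first, only, none or still open, it means among the compounds named here.

Measured compounds:
Compound 1 `NC1=C(C(=O)c2ccccc2)C(c2ccc(Br)cc2)N(CCCn2ccnc2)C1=O` — in a functional assay on A549 cells (Homo sapiens) for antiproliferative activity, read by MTT assay, with a stated time of 72 h (on this read-out higher numbers stand for weaker inhibition and lower numbers for stronger inhibition), compound 1 is reported as "not active" (no number reported), with no number attached.
Compound 2 `Cc1ccc(NC2=C(C(=O)c3ccccc3)C(c3ccc(Br)cc3)N(CCCn3ccnc3)C2=O)cc1` — in this assay compound 2 gives 29400 nM.

For the measured compounds named here, compound 2 thus holds the only number in view. Compound 1 stands next to it with an entry that carries no number, so the two cannot be set against each other. Compound 3 `O=C(C1=C(Nc2ccc(F)cc2)C(=O)N(CCCn2ccnc2)C1c1ccc(Br)cc1)c1ccccc1` has not yet been measured. It differs from compound 2 in one place: fluoro in place of methyl on an aromatic carbon. Going by the values given here, no step between two measured compounds is available, so the size of this exchange cannot be read from the data. What leaves and what enters are each a single heavy atom, and nothing measured shows how such a swap moves this assay here. A shift of a 1.0-fold higher number from compound 2 to compound 3 (0.01 log units; within the scatter) is expected, which is no more than the usual scatter. Compound 3 is therefore estimated at 30000 nM in this assay, within a range from 10000 nM to 90000 nM.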

Compound 3, half-maximal inhibitory concentration: 27400 nM
The estimate for compound 3 lay 1.1-fold (0.04 log units) above the measured number; the range from low to high includes it.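

In this assay, fluoro in place of methyl on an aromatic carbon, para to a large group, gives a 1.1-fold lower number from compound 2 to compound 3 (0.03 log units; within the scatter). For the compounds shown here, this is the first step that can be read between two measured compounds, and it places 4-methylphenyl and 4-fluorophenyl within the scatter of each other, so this exchange at this position does not separate the two compounds. No measurement on hand accounts for this result.

Steps involving compound 1 cannot be read, since its entry carries no number, and the role of the aryl group on the amino nitrogen therefore stays undefined. Also open, going by these compounds, is whether a larger or differently built group at the same place, such as methoxy, a carboxylic acid or a dimethylamino group, would stay within the scatter of compound 2.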